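Removing the Acetyl Group from a Brominated Lactone

A few compounds are considered here, and "the series" means these few. Any claim that something is new, unique, unknown or untested is made for them only; others in the source may bear on it.

Compound 1 `CCC[C@@H](OC(C)=O)C1=C(Br)/C(=C/Br)OC1=O` is the starting point. Within the data shown here, in a functional assay on ZR-75-1 cells (Homo sapiens) for cytotoxicity (a higher number here means that more compound is needed for the effect, a lower number that less compound is needed), compound 1 gives 1.6 ug/mL, the only plain number in this set. Compound 2 `CCC[C@@H](OC(C)=O)C1=C(Br)C(=C(Br)Br)OC1=O` gives in this assay only a limit, not a number, < 0.1 ug/mL. Compound 3 `CCC[C@@H](O)C1=C(Br)/C(=C/Br)OC1=O` has not yet been measured; it differs from compound 1 in one place: hydrogen in place of acetyl on an oxygen on a saturated carbon. Among the measured compounds shown here, no measured pair of compounds shows what such a change does, so no step beyond the usual scatter is expected in either direction. Compound 3 is therefore expected to give about 1.6 ug/mL, most likely between 0.6 ug/mL and 4.5 ug/mL, which means an expected step of no change at the digits printed from compound 1 to compound 3 (within the scatter) within the scatter.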

Compound 3, concentration for half-maximal effect: < 0.1 ug/mL
Compound 3: no number, only a limit; the forecaster's own chance of this, stated with the estimate: 10%; at least 16-fold (1.20 log units) between middle value and limit.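

Swapping acetoxy for hydroxy on this saturated carbon is the first change at this position with a measured outcome, and in this assay it brings an at least 16-fold lower number from compound 1 to compound 3 (1.20 log units; beyond the scatter) in this one pair. The acetyl group is therefore not needed for the effect in these cells, and the free hydroxy does not lose it. Compound 3 gives only a limit, so the step has a minimum size but no known full size: the limit of < 0.1 ug/mL in this assay, at which 2 of the 3 values shown sit.

Still open, as far as these compounds go, is what other groups on this oxygen would do, such as a methyl ether or a longer ester. An amine in place of the oxygen is equally untested in the compounds shown.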